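The compounds below may be only part of what the source reports. "The series", "measured", "known", "first", "only" and "open" are said of these compounds alone.

Among the compounds with values here, in a functional assay on A2780 cells (Homo sapiens) for cytotoxicity, read by sulforhodamine B assay, with a stated time of 72 h (on this read-out higher numbers stand for weaker inhibition and lower numbers for stronger inhibition), compound 1 `O=C(NCc1ccc(S(=O)(=O)c2cccc(C(F)(F)F)c2)cc1)N1Cc2ccncc2C1` gives 2.7 nM, while compound 2 `O=C(NCc1ccc(S(=O)(=O)c2cncc(C(F)(F)F)c2)cc1)N1Cc2ccncc2C1` gives 10 nM, the higher of the two numbers measured so far. Compound 3 `CCCn1cc(S(=O)(=O)c2ccc(CNC(=O)N3Cc4ccncc4C3)cc2)cn1` keeps the rest of compound 2 and differs only on the sulfonyl sulfur, where 1-propyl-1H-pyrazol-4-yl stands in place of 5-(trifluoromethyl)pyridin-3-yl: 1-propyl-1H-pyrazol-4-yl in place of 5-(trifluoromethyl)pyridin-3-yl on a sulfonyl sulfur. Within the data shown here, only one measured step bears on this change, an exchange at the same place: a 3.7-fold higher number from compound 1 to compound 2 (0.57 log units; beyond the scatter). That step is modest but beyond the scatter. It is a single precedent, however, and no group with a five-membered aromatic ring has yet been measured on the sulfonyl sulfur, so it suggests a rough size and only a weak direction. A further modest step is therefore expected in this assay, more likely toward a higher number than a lower one. The estimated change is a 2.0-fold higher number from compound 2 to compound 3 (0.30 log units; within the scatter). For compound 3 the expected value is 20 nM, with an estimated range of 5 nM to 70 nM.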

Compound 3, half-maximal inhibitory concentration: 7.3 nM
For compound 3 the middle estimate is 2.7-fold (0.44 log units) above the measured one; measured number inside the range.
By their numbers in this assay, from the lowest: compound 1; then compounds 3 and 2 (each within the scatter of the next).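

In this assay, the sulfonyl sulfur, whose other neighbour is an aromatic carbon, turns out to tolerate a five-membered aromatic ring carrying a propyl chain: exchanging 5-(trifluoromethyl)pyridin-3-yl for 1-propyl-1H-pyrazol-4-yl gives a 1.4-fold lower number from compound 2 to compound 3 (0.14 log units; within the scatter), so this read-out does not separate the two groups. Set against 3-(trifluoromethyl)phenyl, the same entering group gives a 2.7-fold higher number from compound 1 to compound 3 (0.43 log units; beyond the scatter), which leaves the 3-(trifluoromethyl)phenyl compound with the lowest number of the three, since its steps to both of the others lie beyond the scatter. Nothing available here explains why these three groups fall as they do.

Going by these compounds, what the propyl chain itself contributes remains open, and a methyl group, a butyl chain or a chain ending in an amine on the same pyrazole ring would help to settle it. Also open, on these data alone, is whether an unsubstituted phenyl or a thiazole ring on the sulfonyl sulfur would give numbers closer to that of compound 1 or to those of compound 2 and compound 3.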